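One Group Swapped on a Shared Core

The compounds below may be only part of what the source reports. "The series", "measured", "known", "first", "only" and "open" are said of these compounds alone.

In a functional assay on MCF7 cells (Homo sapiens) for cytotoxicity, read by MTT assay, with a stated time of 72 h (a lower number here means a stronger inhibitor, a higher number a weaker inhibitor), compound 3 `COc1cc2ncnc(Nc3ccc(F)c(Cl)c3)c2cc1NC(=O)N/N=C/c1cc(Br)c(O)c(Br)c1` gives 30200 nM and compound 1 `COc1cc2ncnc(Nc3ccc(F)c(Cl)c3)c2cc1NC(=O)N/N=C/c1ccc([N+](=O)[O-])cc1` gives 36800 nM, so the two cannot be told apart. Compound 2 `COc1cc2ncnc(Nc3ccc(F)c(Cl)c3)c2cc1NC(=O)N/N=C/c1ccc(F)cc1Cl` is reported as "not active" (no number reported), without a number. Compound 4 `CCN(CC)c1ccc(/C=N/NC(=O)Nc2cc3c(Nc4ccc(F)c(Cl)c4)ncnc3cc2OC)c(O)c1` keeps the shared core and changes one group: 4-(diethylamino)-2-hydroxyphenyl in place of 3,5-dibromo-4-hydroxyphenyl on a carbon with a double bond to nitrogen. Among the measured compounds shown here, the one measured step that bears on this, a 1.2-fold lower number from compound 1 to compound 3 (0.09 log units; within the scatter), exchanged groups on the same carbon with a double bond to nitrogen and stayed within the scatter. Compound 2, at "not active" (no number reported), shows that a reported number can also be lost with a change there. The expected change is therefore none beyond the scatter, a 1.1-fold lower number from compound 3 to compound 4 (0.03 log units; within the scatter). For compound 4 the estimated value is 28000 nM, within an expected range of 9000 nM to 80000 nM.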

Compound 4, half-maximal inhibitory concentration: 27300 nM
Compound 4: the middle estimate sits 1.0-fold (0.01 log units) above what was measured; measured number inside the range.
By their numbers in this assay, from the lowest: compounds 4, 3 and 1 (each within the scatter of the next).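

In this assay, the steps of a 1.1-fold lower number from compound 3 to compound 4 (0.04 log units; within the scatter) and a 1.3-fold lower number from compound 1 to compound 4 (0.13 log units; within the scatter) show that even 4-(diethylamino)-2-hydroxyphenyl, with 12 heavy atoms and no bromine, leaves the number within the scatter on this carbon with a double bond to nitrogen. Among the three groups with numbers, the change of group thus separates no compound, while compound 2 goes against this picture, having no number at all. No measurement here explains either result. Still open, as far as these compounds go, is whether a carboxylic acid or a longer chain on this carbon would move the number beyond the scatter.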